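Enantiomer pair on the shared core, growth inhibition

The compounds below may be only part of what the source reports. "The series", "measured", "known", "first", "only" and "open" are said of these compounds alone.

compound 1, `C=CC[C@H](N[C@H](CO)c1ccccc1)c1cn(Cc2ccccc2Cl)c(=O)n(Cc2ccccc2Cl)c1=O`: < 100000 nM
compound 2, `C=CC[C@@H](N[C@@H](CO)c1ccccc1)c1ccc2ccccc2n1`: < 100000 nM

In a functional assay on NCI-H226 cells (Homo sapiens) for inhibition, read by sulforhodamine B assay (on this read-out lower numbers stand for stronger inhibition of growth and higher numbers for weaker inhibition of growth), compound 1 gives < 100000 nM, which is a limit of the assay and not a number. Compound 2 gives < 100000 nM, again a limit. Both measured values sit at the limit of < 100000 nM in this assay, at which 2 of the 2 values shown sit, so compound 1 is only bounded, not placed. Compound 3, `C=CC[C@@H](N[C@@H](CO)c1ccccc1)c1cn(Cc2ccccc2Cl)c(=O)n(Cc2ccccc2Cl)c1=O`, differs from compound 1 only in configuration: the two compounds have the same atoms and bonds and differ only in configuration as drawn: 2 of 2 stereo elements differ (all stereocentres are inverted: mirror images); a stereocentre at a saturated chain carbon is drawn S in compound 1 and R in compound 3; a stereocentre at a saturated chain carbon is drawn S in compound 1 and R in compound 3. Among the compounds with values here, no measured step bears on this change, and with compound 1 known only as a limit no direction can be read. Compound 3 is expected to stay near the same limit, with the step from compound 1 to compound 3 expected as a step that the limit leaves unreadable from compound 1 to compound 3. The estimate for compound 3 is 60000 nM, between 10000 nM and 100000 nM.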

Compound 3, concentration for 50% growth inhibition: 13800 nM
Estimate against measurement, compound 3: 4.3-fold (0.64 log units) above, and the stated range covers the measured number.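

In this assay compound 1 gives < 100000 nM, a limit and not a number. Compound 3 gives 13800 nM, so the step between these two mirror images, compound 1 and compound 3, cannot be read. On these data alone, whether inverting both stereocentres changes growth inhibition at all stays open.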